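The compounds below may be only part of what the source reports. "The series", "measured", "known", "first", "only" and "open" are said of these compounds alone.

In a functional assay for inhibition, with Homo sapiens as the target (a lower number here means a stronger inhibitor, a higher number a weaker inhibitor), three compounds share one core and differ in the ring on a saturated chain carbon bound to a nitrogen on an aromatic ring and a saturated chain carbon. Compound 1 `Cc1ccc2oc(NC(CC3CCCCC3)C3=CN(C)NO3)nc2c1` gives 26 nM, compound 2 `Cc1ccc2oc(NC(CC3CCCCC3)c3ccccn3)nc2c1` gives 4 nM, and compound 3 `Cc1ccc2oc(NC(CC3CCCCC3)c3cccnc3)nc2c1` gives 20 nM. Two of these numbers cannot be told apart, since a 1.3-fold lower number from compound 1 to compound 3 (0.11 log units; within the scatter) lies within the scatter. Compound 3 therefore stands at the weaker end of this small set, together with compound 1, and compound 2 is the strongest inhibitor of the three.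

Compound 4 `Cc1ccc2oc(NC(CC3CCCCC3)c3ccncc3)nc2c1` has the same atoms as compound 3, joined differently: pyridin-4-yl in place of pyridin-3-yl on a saturated chain carbon bound to a nitrogen on an aromatic ring and a saturated chain carbon. The closest measured precedent is the change between pyridin-2-yl and pyridin-3-yl, a 5.0-fold higher number from compound 2 to compound 3 (0.70 log units; beyond the scatter), a modest step beyond the scatter. It shows that the number can shift when the ring is attached differently. Within the data shown here, no compound with pyridin-4-yl has been measured, however, so the data give no direction for this change. The estimated step is no change at the digits printed from compound 3 to compound 4 (within the scatter), so no change beyond the scatter is expected, although a modest step either way remains possible. For compound 4 the estimated value is 20 nM, with an expected range from 6 nM to 60 nM.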

Compound 4, half-maximal inhibitory concentration: 190 nM
For compound 4 the middle estimate is 9.5-fold (0.98 log units) below the measured one; the measured number lies above the stated range.
By their numbers in this assay, from the lowest: compound 2; then compounds 3 and 1 (each within the scatter of the next); then compound 4.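

In this assay the way the pyridine ring is attached at this position turns out to matter more than the first pair suggested: a 9.5-fold higher number from compound 3 to compound 4 (0.98 log units; beyond the scatter) is a step of similar size to the earlier change, and a 48-fold higher number from compound 2 to compound 4 (1.68 log units; beyond the scatter) is the largest step in the set, so pyridin-2-yl, pyridin-3-yl and pyridin-4-yl now give three numbers that are each beyond the scatter of the others. Compound 3 could not be told apart from compound 1, yet a 7.3-fold higher number from compound 1 to compound 4 (0.86 log units; beyond the scatter) separates the new isomer from that compound too, which leaves compound 4 as the weakest inhibitor of the four even though it has the same atoms as compound 3. Nothing available explains why these isomers differ in this way.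

The compounds shown leave open whether a phenyl ring, with carbon in place of the ring nitrogen, would sit nearer to compound 2 or to compound 4. They also leave open whether the order of the three pyridines would hold with a methoxy group or an amine on the ring, or with a longer chain in place of the cyclohexylmethyl group.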